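The source may hold more compounds than are shown below. What is called first, only, known or untested is meant among the compounds shown, and "the series" means these compounds.

Measured so far in a functional assay on HeLa cells (Homo sapiens) for inhibition, read by sulforhodamine B assay; on this read-out higher numbers stand for weaker inhibition and lower numbers for stronger inhibition:
- compound 1 `O=C1C=C(N2CCC2)C(=O)c2c1nc1n2[C@H]2OC[C@@H](O)[C@H]2OC1`: > 16000 nM
- compound 2 `O=C1C=C(Nc2cccc(F)c2)C(=O)c2c1nc1n2[C@H]2OC[C@@H](O)[C@H]2OC1`: 6440 nM

The entry for compound 1 is a limit of this assay and not a number. Among the measured compounds shown here, that leaves compound 2 as the only compound with a numeric value, so it is the sole firm anchor for the series.

Compound 3 `O=C1C=C(NC2CCCC2)C(=O)c2c1nc1n2[C@H]2OC[C@@H](O)[C@H]2OC1` keeps the shared core and changes one group: cyclopentyl in place of 3-fluorophenyl on an amine nitrogen.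

For the measured compounds named here, one measured step bears on this: an at least 2.4-fold lower number from compound 1 to compound 2 (0.39 log units; beyond the scatter), with (3-fluorophenyl)amino in place of azetidin-1-yl on a double-bonded ring carbon. Going by these compounds, one end of that step is a limit, so its full size remains open. Going by the values given here, it is also a different exchange, and no measured compound carries cyclopentylamino, so it transfers only loosely. Removing the 3-fluorophenyl group from compound 2 is therefore expected to give a modest move to a higher number in this assay, though a change within the scatter remains possible. The expected step is a 1.5-fold higher number from compound 2 to compound 3 (0.17 log units; within the scatter). For compound 3 the estimated value is 9500 nM, with an expected range of 3500 nM to 22000 nM.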

Compound 3, half-maximal inhibitory concentration: > 16000 nM
Compound 3: only a limit was reported; the forecaster's own chance of this, stated with the estimate: 30%; at least 1.6-fold (0.22 log units) between middle value and limit.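

In this assay, exchanging 3-fluorophenyl for cyclopentyl on an amine nitrogen gives an at least 2.4-fold higher number from compound 2 to compound 3 (0.39 log units; beyond the scatter), so keeping the amine nitrogen is not enough to retain the reading of compound 2, and a non-aromatic carbon ring of five members does not stand in for the aromatic ring here. The entry for compound 3 is a limit and not a number, so this step fixes a direction and a minimum size only, and the step between compound 1 and compound 3 cannot be read. Of the three compounds, only compound 2, the one with an aromatic ring on the nitrogen, gives a numeric value, and the two others end at the same limit: the limit of > 16000 nM in this assay, at which 2 of the 3 values shown sit.

Going by these compounds, what remains open is whether the step follows from the aromatic ring or from its fluorine, a question that plain phenyl, 3-chlorophenyl or 4-fluorophenyl on the same nitrogen would address. The true size of the step is also unresolved, as is the reading of a benzyl group or a longer alkyl chain at this nitrogen.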